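The source may hold more compounds than are shown below. What is called first, only, known or untested is meant among the compounds shown, and "the series" means these compounds.

Of the compounds shown here, three of one shared core have been tested in a functional assay on the whole organism (artery, strain albino) with Rattus norvegicus as the target, with a stated time of 720 min, at a dose of 10 mg/kg by the oral route; a higher number here means more inhibition at the dose given (going by the name of the read-out), a lower number less inhibition. Compound 1 `CC1=C(C(=O)Nc2ccc(F)cc2)C(c2ccc([N+](=O)[O-])cc2)N=C(SCc2cccc(Cl)c2)N1` gives 12.9%, and compound 2 `CC1=C(C(=O)Nc2ccc(F)cc2)C(c2ccc([N+](=O)[O-])cc2)N=C(SCc2ccc(Cl)cc2)N1` gives 22.2%. The two differ in one place: 4-chlorophenyl in place of 3-chlorophenyl on a saturated chain carbon bound to a sulfur. That change made a step of a number 9.3 percentage points higher from compound 1 to compound 2 (within the scatter). Compound 3 `COc1ccc(C2N=C(SCc3cccc(Cl)c3)NC(C)=C2C(=O)Nc2ccc(Br)cc2)cc1` gives 26.8%; its core differs from the core of compound 1 in more than one place, and the difference between the two cores is not broken down here.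

Compound 4 `COc1ccc(C2N=C(SCc3ccc(Cl)cc3)NC(C)=C2C(=O)Nc2ccc(Br)cc2)cc1` has not yet been measured in this assay. It stands to compound 3 as compound 2 stands to compound 1: 4-chlorophenyl in place of 3-chlorophenyl on a saturated chain carbon bound to a sulfur. Because the same change gave a number 9.3 percentage points higher from compound 1 to compound 2 (within the scatter), a step of about the same size is expected here, though a single earlier step that lies within the scatter is a weak guide. The expected step from compound 3 to compound 4 is a number 6.2 percentage points higher from compound 3 to compound 4 (within the scatter). On that basis compound 4 is estimated at 33% in this assay, within a range from 18% to 48%.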

Compound 4, a percentage reported as inhibition, in the whole organism at one dose (the size of the read-out at that dose, not a potency): 23.7%
Estimate against measurement, compound 4: 9.3 percentage points above; measured number inside the range.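

In this assay, putting 4-chlorophenyl in place of 3-chlorophenyl on a saturated chain carbon bound to a sulfur gave a number 3.1 percentage points lower from compound 3 to compound 4 (within the scatter) on the core of compound 3, so this step, like the earlier one, cannot be told apart from the ordinary spread of repeated measurements. The two steps point in opposite directions, yet the gap between them is no larger than two such uncertain steps can produce: the same change on two cores in this assay, a number 9.3 percentage points higher (within the scatter) from compound 1 to compound 2 and a number 3.1 percentage points lower (within the scatter) from compound 3 to compound 4, 12.4 percentage points apart, within the scatter of two such steps. This shows no clear effect of the change on either core, but it does not show that the change truly does nothing, nor that the two cores respond alike or differently.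

The compounds shown leave open whether an amine, a carboxylic acid or a longer chain in place of the chlorophenyl group would shift the inhibition by more than the scatter. They also do not separate the several places in which the core of compound 1 and the core of compound 3 differ.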